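The source may report more compounds than this note shows. Statements on the series, on what has been measured and on what is new or still open speak of the compounds shown alone.

Of the compounds shown here, three have been tested in a functional assay on the whole organism with Mus musculus as the target (a lower number here means that less compound is needed, a higher number that more compound is needed for the effect), and a fourth awaits measurement. Compound 1 `Cc1ccccc1Oc1ccc2nncn2n1` and compound 3 `Clc1ccccc1Oc1ccc2nncn2n1` share one core and differ in a single spot: chloro in place of methyl on an aromatic carbon. In this assay compound 1 gives 54.8 mg/kg and compound 3 gives 47.3 mg/kg. Between them the result was a 1.2-fold lower number from compound 1 to compound 3 (0.06 log units; within the scatter), so the two values cannot be told apart. Compound 2 `Cc1cccc(Oc2ccc3nncn3n2)c1` is made of the same atoms as compound 1, joined differently, and the difference between the two cores is not broken down here. In this assay compound 2 gives only a limit of the assay, > 100 mg/kg. That value is the limit of > 100 mg/kg in this assay, at which 1 of the 3 values shown sits, so no number is available for compound 2.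

Compound 4 `Clc1cccc(Oc2ccc3nncn3n2)c1` has not yet been measured. It differs from compound 2 by the same kind of change as that between compound 1 and compound 3: chloro in place of methyl on an aromatic carbon. The surroundings are not identical, though: here the place is meta to a large group, whereas for the earlier pair it was ortho to a large group. Because a 1.2-fold lower number from compound 1 to compound 3 (0.06 log units; within the scatter) lay within the scatter, a similarly small step is expected here, a step that the limit leaves unreadable from compound 2 to compound 4. Compound 4 is therefore expected to land around 150 mg/kg, somewhere between 50 mg/kg and 500 mg/kg, with a real chance that this assay again reports only a limit rather than a number.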

Compound 4, dose for half-maximal effect: 39.4 mg/kg
Beside the measured number, compound 4's estimate is 3.8-fold (0.58 log units) above it, outside the stated range (below it).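

In this assay, chloro in place of methyl on an aromatic carbon, meta to a large group, gave an at least 2.5-fold lower number from compound 2 to compound 4 (0.40 log units; beyond the scatter), while the same kind of change on the other core gave a 1.2-fold lower number from compound 1 to compound 3 (0.06 log units; within the scatter). Set side by side, these two steps show that the change can lower the dose needed on at least one of these cores, but they do not settle whether it behaves alike on both: the same change on two cores in this assay, a 1.2-fold lower number (0.06 log units; within the scatter) from compound 1 to compound 3 and an at least 2.5-fold lower number (0.40 log units; beyond the scatter) from compound 2 to compound 4; the limit leaves it open whether they differ Compound 2 has only a limit of the assay, > 100 mg/kg, so the step from it has a lower bound but no known size, and the pair cannot show how much of the change carries over from one core to the other.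

The compounds shown carry only methyl or chloro on the six-membered aromatic ring, so it stays open whether a methoxy group, a trifluoromethyl group or an amine in these places would follow chloro or methyl. As far as these compounds go, how the dose would respond to changes on the shared core itself, such as a longer chain attached there, also stays open.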